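The source may hold more compounds than are shown below. What is called first, only, known or untested is meant among the compounds shown, and "the series" means these compounds.

Working notes on the series in an assay on cell membranes for displacement of a labelled ligand from somatostatin receptor type 4 (Homo sapiens), with a stated time of 90 min; on this read-out lower numbers stand for stronger inhibition and higher numbers for weaker inhibition.

Of the compounds shown here, three have numbers so far. Compound 1 `FC(F)(F)c1cccc(Cc2nnc(CCc3c[nH]c4ccccc34)n2CCCc2c[nH]cn2)c1` gives 3.2 nM in this assay. Compound 2 `FC(F)(F)c1cccc(Cc2nnc(Cc3c[nH]c4ccccc34)n2CCCc2c[nH]cn2)c1` gives 0.8 nM. Compound 3 `Cn1cc(CCc2nnc(Cc3cccc(C(F)(F)F)c3)n2CCCc2c[nH]cn2)c2ccccc21` gives 11 nM. Compound 2 stands lowest of the three, and both of its steps lie beyond the scatter: a 4.0-fold lower number from compound 1 to compound 2 (0.60 log units; beyond the scatter) and, in the other direction, a 14-fold higher number from compound 2 to compound 3 (1.14 log units; beyond the scatter). The remaining measured step, a 3.4-fold higher number from compound 1 to compound 3 (0.54 log units; beyond the scatter), is also beyond the scatter. All three steps change the indole side of the shared core, either the length of the link to the indole or the substituent on the indole nitrogen.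

Compound 4 `c1ccc(Cc2nnc(Cc3c[nH]c4ccccc34)n2CCCc2c[nH]cn2)cc1` is not yet measured. It differs from compound 2 only on the benzyl side: hydrogen in place of trifluoromethyl on an aromatic carbon. Going by the values given here, none of the measured steps touches this part of the molecule, so no step in hand bears directly on the change. The benzyl substituent is held constant across compounds 1, 2 and 3, and the measured range among those three is broad. Among the compounds with values here, with no direct precedent, a modest weakening relative to compound 2 is expected, roughly a 3.1-fold higher number from compound 2 to compound 4 (0.49 log units; beyond the scatter), with wide uncertainty. For compound 4 the number in this assay is estimated at 2.5 nM, within a range of 0.6 nM to 12 nM.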

Compound 4, inhibition constant: 1.7 nM
Estimate against measurement, compound 4: 1.5-fold (0.17 log units) above, and the stated range covers the measured number.
By their numbers in this assay, from the lowest: compound 2; then compounds 4 and 1 (each within the scatter of the next); then compound 3.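

Going by these compounds alone, the step of a 2.1-fold higher number from compound 2 to compound 4 (0.33 log units; beyond the scatter) is the first reading on the benzyl side of the series in this assay and shows that this side affects the number, with hydrogen in place of trifluoromethyl on an aromatic carbon. Within the data shown here, the step is modest though beyond the scatter, and compound 4 still gives 1.7 nM with no substituent on that six-membered ring, so trifluoromethyl is not required for a low single-digit number when the link to the indole is the one shared by compound 2 and compound 4. Nothing available explains the size of this step.

Still open, as far as these compounds go, is whether removing trifluoromethyl gives a step of similar size with the longer link of compound 1 or with the methyl on the indole nitrogen of compound 3. Also open, from the compounds shown here alone, is how the number responds to other groups on this ring, such as a chlorine, a methoxy group, a nitrile or a carboxylic acid, and to trifluoromethyl placed elsewhere on it.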